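Methyl for Phenyl on the Ring Nitrogen

The compounds below may be only part of what the source reports. "The series", "measured", "known", "first", "only" and "open" are said of these compounds alone.

Three measured compounds share one core and differ only at a saturated ring carbon: compound 1 `C=C1C(=O)N(c2ccccc2)N(c2ccccc2)C1c1ccccc1` carries a phenyl there, compound 2 `C=C1C(=O)N(c2ccccc2)N(c2ccccc2)C1CC` an ethyl, and compound 3 `C=C1C(=O)N(c2ccccc2)N(c2ccccc2)C1C` a methyl. In a functional assay on HL-60 cells (Homo sapiens) for inhibition, read by MTT assay, with a stated time of 48 h (on this read-out lower numbers stand for stronger inhibition and higher numbers for weaker inhibition), compound 1 gives 1610 nM. Compound 2 gives 8890 nM, and compound 3 gives 5850 nM. Compound 2 thus stands at the highest number of the three; the nearest to it is a 1.5-fold lower number from compound 2 to compound 3 (0.18 log units; within the scatter), and the furthest is a 5.5-fold higher number from compound 1 to compound 2 (0.74 log units; beyond the scatter).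

Compound 4 `C=C1C(=O)N(c2ccccc2)N(C)C1CC` is the next candidate, and it changes compound 2 at a different site: methyl in place of phenyl on an amine nitrogen in a ring. For the measured compounds named here, none of the measured steps touches this ring nitrogen, so no step bears on it directly. The closest analogy is the exchange of phenyl for a small alkyl at the ring carbon, seen in a 5.5-fold higher number from compound 1 to compound 2 (0.74 log units; beyond the scatter) and a 3.6-fold higher number from compound 1 to compound 3 (0.56 log units; beyond the scatter), both of which raised the number. Taking that as the only guide, a step of similar direction and size is expected, a 2.0-fold higher number from compound 2 to compound 4 (0.31 log units; beyond the scatter). Compound 4 is therefore estimated at 18000 nM, with a range from 5000 nM to 50000 nM.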

Compound 4, half-maximal inhibitory concentration: 750000 nM
For compound 4 the middle estimate is 42-fold (1.62 log units) below the measured one, outside the stated range (above it).
By their numbers in this assay, from the lowest: compound 1; then compounds 3 and 2 (each within the scatter of the next); then compound 4.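

For the compounds shown here, at this amine nitrogen in a ring, the phenyl group counts for far more than anything the earlier compounds varied: in this assay, methyl in place of phenyl gives an 84-fold higher number from compound 2 to compound 4 (1.93 log units; beyond the scatter), the only large step. The same kind of exchange on the saturated ring carbon gave only a modest change, a 5.5-fold higher number from compound 1 to compound 2 (0.74 log units; beyond the scatter), so the two sites do not respond alike and the size of a step at one does not carry over to the other. Nothing available explains why the ring nitrogen is so much more demanding here.

The compounds shown have only phenyl or methyl on this ring nitrogen, so they leave open whether an ethyl, a propyl chain or a benzyl there would stay close to compound 2 or fall close to compound 4. They also leave open whether the exchange would be as large with phenyl rather than ethyl on the saturated ring carbon, the arrangement of compound 1.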